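A Methyl Branch on the Chain of Compound 3

The source may hold more compounds than are shown below. What is called first, only, known or untested is meant among the compounds shown, and "the series" means these compounds.

Compound 1 `C/N=C(\S)CCn1nc(-c2ccccc2)ccc1=O`, compound 2 `CC/N=C(\S)CCn1nc(-c2ccccc2)ccc1=O` and compound 3 `C/N=C(\S)CCn1ncccc1=O` have been tested in a functional assay on the whole organism (stomach) with Rattus norvegicus as the target; on this read-out lower numbers stand for an effect already at smaller amounts and higher numbers for an effect only at larger amounts of compound. Compound 1 gives 58.5 mg/kg, and compound 2 gives 100 mg/kg. For compound 3 the result is a limit and not a number, > 100 mg/kg. Compound 2 differs from compound 1 by methyl in place of hydrogen on a saturated chain carbon bound to a double-bonded nitrogen, a step of a 1.7-fold higher number from compound 1 to compound 2 (0.23 log units; within the scatter). Compound 3 differs from compound 1 by hydrogen in place of phenyl on an aromatic carbon, a step of an at least 1.7-fold higher number from compound 1 to compound 3 (0.23 log units; that floor lies within the scatter) that rests on (the limit of > 100 mg/kg in this assay, at which 1 of the 3 values shown sits). Compound 4 `C/N=C(\S)CC(C)n1ncccc1=O`, still unmeasured, differs from compound 3 by methyl in place of hydrogen on a saturated chain carbon bound to an aromatic nitrogen and a saturated chain carbon. This is the same kind of change as from compound 1 to compound 2, though the place differs: there the carbon is bound to a double-bonded nitrogen, here to an aromatic nitrogen and a saturated chain carbon. Because a 1.7-fold higher number from compound 1 to compound 2 (0.23 log units; within the scatter) stayed within the scatter, compound 4 is expected to stay close to compound 3, a step that the limit leaves unreadable from compound 3 to compound 4. Compound 4 is estimated in this assay at 150 mg/kg, between 60 mg/kg and 500 mg/kg.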

Compound 4, dose for half-maximal effect: > 100 mg/kg
Compound 4 gave a limit, no number; the forecaster's own chance of this, stated with the estimate: 70%; the middle value lies beyond the limit too.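

In this assay, among these compounds, compound 3 and compound 4 both end at a limit and not a number, so no step between them can be read: the limit of > 100 mg/kg in this assay, at which 2 of the 4 values shown sit. From the compounds shown here alone, whether the added methyl changes the effective dose of compound 4 relative to compound 3 stays open.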